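The compounds below may be only part of what the source reports. "The series", "measured", "known", "first", "only" and "open" are said of these compounds alone.

Measured in an assay on CHO cells for displacement of a labelled ligand from adenosine receptor A1 (Homo sapiens), read by scintillation counting, tested at 10 uM; on this read-out higher numbers stand for more inhibition at the one concentration tested (going by the name of the read-out) and lower numbers for less inhibition:

compound 1 `CC(C)(C)Cc1csc(N)c1C(=O)c1ccc(Cl)cc1`: 1%
compound 2 `CC(C)(C)Cc1c(-c2ccc(OC(F)(F)F)cc2)sc(N)c1C(=O)c1ccc(Cl)cc1`: 1%
compound 3 `Cc1ccccc1-c1sc(N)c(C(=O)c2ccc(Cl)cc2)c1CC(C)(C)C`: 1%

All three measured compounds share one core and show essentially no displacement of the labelled ligand at the single concentration tested. Compound 1 stands level with compound 2 and compound 3 at the digits shown; its nearest neighbour is compound 2 and its furthest is compound 3, and neither gap is beyond the usual scatter of this read-out.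

Compound 4 `CC(C)(C)Cc1c(-c2ccccc2)sc(N)c1C(=O)c1ccc(Cl)cc1` is the next compound to be measured. It differs from compound 1 by a single change: phenyl in place of hydrogen on an aromatic carbon.

One measured step speaks directly to this change. Going from compound 1 to compound 3 put 2-methylphenyl in place of hydrogen on an aromatic carbon of the core, and that step gave no change at the digits printed from compound 1 to compound 3 (within the scatter). Compound 2, which also carries a substituted phenyl on the core, sits at the same level as compound 1. Nothing in these values suggests that attaching an unsubstituted phenyl would lift or lower the read-out beyond the scatter, so the expected step from compound 1 to compound 4 is no change at the digits printed from compound 1 to compound 4 (within the scatter), meaning essentially none. Compound 4 is therefore estimated at 1%, with a range from -8% to 10%.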

Compound 4, a percentage reported as inhibition, at one concentration (the size of the read-out at that concentration, not a potency): 1%
Beside the measured number, compound 4's estimate shows no gap at the digits printed, within the range that was stated.
By their numbers in this assay, from the lowest: compounds 1, 2, 3 and 4 (each within the scatter of the next).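

In this assay, an unsubstituted phenyl on the aromatic carbon next to the ring sulfur gives no change at the digits printed from compound 1 to compound 4 (within the scatter), so the plain ring now joins the two substituted rings already seen at this position. Hydrogen in place of the methyl gives no change at the digits printed from compound 3 to compound 4 (within the scatter) and hydrogen in place of the trifluoromethoxy gives no change at the digits printed from compound 2 to compound 4 (within the scatter), so neither ring substituent separates from the bare phenyl on this read-out, where all four compounds show almost no displacement of the labelled ligand. Nothing available explains this flat picture.

Still open, from the compounds shown here alone, is whether a phenyl carrying an amine or a carboxylic acid would change the read-out at this position. A longer chain in place of the phenyl is equally untested by the compounds shown here.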